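Chain amine in place of pyrrolidine on the shared core

The source may report more compounds than this note shows. Statements on the series, on what has been measured and on what is new or still open speak of the compounds shown alone.

The series keeps one core and varies only the chain on the aromatic nitrogen, as in compound 1 `O=C1c2c[n+]([O-])c3ccccc3c2C(=O)c2c1c1ccccc1n2Cc1cn(C[C@@H](O)CO)nn1`, compound 2 `CN(C)CCCCn1c2c(c3ccccc31)C(=O)c1c[n+]([O-])c3ccccc3c1C2=O` and compound 3 `O=C1c2c[n+]([O-])c3ccccc3c2C(=O)c2c1c1ccccc1n2CCN1CCCC1`. In a functional assay on SH-SY5Y cells (Homo sapiens) for cytotoxicity, read by MTT assay, with a stated time of 72 h (a lower number here means a stronger inhibitor, a higher number a weaker inhibitor), compound 1 gives > 500 nM, a limit of the assay rather than a number. In this assay compound 2 gives 250 nM. In this assay compound 3 gives 520 nM, the higher of the two numbers; its nearest neighbour is compound 2, with a 2.1-fold higher number from compound 2 to compound 3 (0.32 log units; beyond the scatter).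

Compound 4 `CN(C)CCCCCn1c2c(c3ccccc31)C(=O)c1c[n+]([O-])c3ccccc3c1C2=O` is not yet measured in this assay. Its difference from compound 3: 3-(dimethylamino)propyl in place of pyrrolidin-1-yl on a saturated chain carbon, two bonds along the chain from an aromatic nitrogen. Among the measured compounds shown here, two measured steps bear on this. The step of a 2.1-fold higher number from compound 2 to compound 3 (0.32 log units; beyond the scatter) is the closest, the same two groups in the reverse direction, compound 4 carrying 4-(dimethylamino)butyl where compound 2 carries 3-(dimethylamino)propyl. The step of an at least 2.0-fold lower number from compound 1 to compound 2 (0.30 log units; that floor lies within the scatter) also ends on a dimethylamino chain, but starts from a limit and gives only a floor. Reversing the first step points to a modest lower number. The expected step is a 1.9-fold lower number from compound 3 to compound 4 (0.27 log units; within the scatter). In this assay compound 4 is expected to give 280 nM, with a range from 120 nM to 650 nM.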

Compound 4, half-maximal inhibitory concentration: 370 nM
Compound 4: middle estimate off by 1.3-fold (0.12 log units), on the low side, within the range that was stated.
By their numbers in this assay, from the lowest: compounds 2, 4 and 3 (each within the scatter of the next, the first and the last beyond it).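

At the saturated chain carbon two bonds along the chain from an aromatic nitrogen, 3-(dimethylamino)propyl in place of pyrrolidin-1-yl gives, in this assay, a 1.4-fold lower number from compound 3 to compound 4 (0.15 log units; within the scatter), and the dimethylamino pair gives a 1.5-fold higher number from compound 2 to compound 4 (0.17 log units; within the scatter). Compound 4 therefore lies within the scatter of both neighbours, so the gap of a 2.1-fold higher number from compound 2 to compound 3 (0.32 log units; beyond the scatter) cannot be assigned to either the chain length or the ring alone. Compound 1 is held at a limit of the assay, not a number, and its comparison gives only a floor, an at least 1.3-fold lower number from compound 1 to compound 4 (0.13 log units; that floor lies within the scatter), with the limit reading: the limit of > 500 nM in this assay, at which 1 of the 4 values shown sits.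

As far as these compounds go, a pyrrolidine ring on a longer chain would separate ring from chain length, and that comparison remains open. From the compounds shown here alone, how a morpholine or a primary amine at the chain end would read in this assay also remains open.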